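From 4-methylphenyl to 4-chloro-2,5-dimethylphenyl on compound 1

This account rests on a few compounds, and the source may have more. Where it says the series, first, only, none or still open, it means among the compounds named here.

As far as these compounds go, in an in vitro ADME assay on microsomes from liver (Homo sapiens) for pharmacokinetics (a higher number here means faster removal of the compound, a lower number slower removal), compound 1 `Cc1ccc(S(=O)(=O)N2C=CNC(=O)[C@H]2CC(=O)N[C@H]2CCN(C)CC2(C)C)cc1` reports < 14 mL.min-1.g-1 as a limit and not a number, so its exact place is unknown. Compound 2 `CCCN1CC[C@H](NC(=O)C[C@@H]2C(=O)NC=CN2S(=O)(=O)c2ccc(C)cc2)C(C)(C)C1` likewise gives only a limit with < 50 mL.min-1.g-1 as its reading. Compound 3 `Cc1ccc(S(=O)(=O)N2C=CNC(=O)[C@H]2CC(=O)N[C@H]2CCN(C3CCC3)CC2(C)C)cc1` gives a true number with 24 mL.min-1.g-1 as its reading.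

Compound 4 `Cc1cc(S(=O)(=O)N2C=CNC(=O)[C@H]2CC(=O)N[C@H]2CCN(C)CC2(C)C)c(C)cc1Cl` differs from compound 1 only on the sulfonyl sulfur, where 4-chloro-2,5-dimethylphenyl stands in place of 4-methylphenyl. The change is 4-chloro-2,5-dimethylphenyl in place of 4-methylphenyl on a sulfonyl sulfur and the rest stays as it was.

Among the measured compounds shown here, no measured step touches this group, since all of them change the end carrying the amine nitrogen in a ring. Two of them, a step that the two limits leave unreadable from compound 1 to compound 2 and a step that the limit leaves unreadable from compound 2 to compound 3 show no size. Going by an at least 1.7-fold higher number from compound 1 to compound 3 (0.23 log units; that floor lies within the scatter) as the only loose guide, a small rise is expected for compound 4, which may still report a limit. The expected step is an at least 1.4-fold higher number from compound 1 to compound 4 (0.15 log units; that floor lies within the scatter) as an estimate. Compound 4 is estimated at 20 mL.min-1.g-1 with an expected range from 9 mL.min-1.g-1 to 45 mL.min-1.g-1 in this assay overall.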

Compound 4, intrinsic clearance in microsomes: 87 mL.min-1.g-1
Compound 4: the middle estimate sits 4.4-fold (0.64 log units) below what was measured; measured number outside the range, above it.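

In this assay, among the compounds shown here, the change on the sulfonyl sulfur gives an at least 6.2-fold higher number from compound 1 to compound 4 (0.79 log units; beyond the scatter), so this end of the molecule, which no earlier step touched, can move clearance beyond the scatter. For the compounds shown here, the only earlier step with any readable size, on the amine nitrogen in a ring, was an at least 1.7-fold higher number from compound 1 to compound 3 (0.23 log units; that floor lies within the scatter). The true size of the new step stays unknown because compound 1 reports only a limit: the limit of < 14 mL.min-1.g-1 in this assay, at which 1 of the 4 values shown sits.

The 4-chloro-2,5-dimethylphenyl group brings in chlorine and extra methyl groups in a single change, so the compounds shown cannot say which of these carries the rise, and a plain 4-chlorophenyl group on the sulfonyl sulfur would help separate them. As far as these compounds go, the steps involving compound 2 cannot be read, so the effect of the propyl group on the amine nitrogen also stays open.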